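This account rests on a few compounds, and the source may have more. Where it says the series, first, only, none or still open, it means among the compounds named here.

In a functional assay (Cavia porcellus) with sulfonylurea receptors; K-ATP channels (Homo sapiens) as the target (a higher number here means a weaker inhibitor, a lower number a stronger inhibitor), compound 1 `CC(O)(C(=O)Nc1ccc(S(=O)(=O)c2ccccc2O)cc1)C(F)(F)F` gives 3090 nM. Compound 2 `Cc1ccc(S(=O)(=O)c2ccc(NC(=O)C(C)(O)C(F)(F)F)cc2)cc1` reaches only the assay limit of > 30000 nM, so no number is known for it (the limit of > 30000 nM in this assay, at which 1 of the 2 values shown sits). For the measured compounds named here, the single measured step is an at least 9.7-fold higher number from compound 1 to compound 2 (0.98 log units; beyond the scatter), the loss of the 2-hydroxyphenyl. Compound 3 `CC(O)(C(=O)Nc1ccc(S(=O)(=O)c2nccs2)cc1)C(F)(F)F` differs from compound 2 by 1,3-thiazol-2-yl in place of 4-methylphenyl on a sulfonyl sulfur. No measured step covers a ring of this kind, and the one step shown leaves both rings without a hydroxyl at weak inhibition. Compound 3 is therefore expected to remain weak, with an estimated step of an at least 1.5-fold lower number from compound 2 to compound 3 (0.17 log units; that floor lies within the scatter) and an estimate of 20000 nM, between 4000 nM and 60000 nM.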

Compound 3, half-maximal inhibitory concentration: 1400 nM
Estimate against measurement, compound 3: 14-fold (1.15 log units) above; measured number outside the range, below it.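

On a sulfonyl sulfur, a hydroxyl on the ring is not required for inhibition in this assay: the 1,3-thiazol-2-yl, which has no hydrogen-bond donor, gives an at least 21-fold lower number from compound 2 to compound 3 (1.33 log units; beyond the scatter), and also a 2.2-fold lower number from compound 1 to compound 3 (0.34 log units; beyond the scatter). The first of these steps is only a floor, as compound 2 stands at a limit: the limit of > 30000 nM in this assay, at which 1 of the 3 values shown sits.

The compounds shown leave open whether the gain belongs to the ring nitrogen, the ring sulfur or the five-membered ring itself. They also leave open how a pyridine ring, or a phenyl carrying an amine, would compare at this place.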